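The compounds below may be only part of what the source reports. "The series", "measured", "known", "first", "only" and "open" are said of these compounds alone.

Measured in an assay on SH-EP1 cells for agonist activity at Neuronal acetylcholine receptor; alpha4/beta2 (Homo sapiens), read by FLIPR and calcium flux; on this read-out lower numbers stand for an effect already at smaller amounts and higher numbers for an effect only at larger amounts of compound:
compound 1 `O=C(C1CCCC1)N1CC2CC(C1)N2` gives 29000 nM
compound 2 `O=C(CC1C=CCC1)N1CC2CC(C1)N2` gives 37000 nM
compound 3 `O=C([C@H]1C[C@H]1F)N1CC2CC(C1)N2` gives 1500 nM

Compound 3 has the lowest number of the three; the nearest value, that of compound 1, and the furthest, that of compound 2, both sit beyond the scatter from it. Compound 4 `C[C@@H]1C[C@H]1C(=O)N1CC2CC(C1)N2` has not yet been measured in this assay. Its change from compound 3 is 2-methylcyclopropyl in place of 2-fluorocyclopropyl on a carbonyl carbon. Among the measured compounds shown here, no measured pair shows a change of this kind, so the size of the step is open. For compound 4 the expected step is a 2.7-fold higher number from compound 3 to compound 4 (0.43 log units; beyond the scatter), a moderate move toward a higher number that is expected to leave it well apart from compound 1 and compound 2. The estimate for compound 4 in this assay is 4000 nM, with a range from 1200 nM to 15000 nM.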

Compound 4, half-maximal effective concentration: 2900 nM
Compound 4: middle estimate off by 1.4-fold (0.14 log units), on the high side, and the stated range covers the measured number.
By their numbers in this assay, from the lowest: compounds 3 and 4 (each within the scatter of the next); then compounds 1 and 2 (each within the scatter of the next).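

In this assay, the swap of 2-fluorocyclopropyl for 2-methylcyclopropyl on a carbonyl carbon gives a 1.9-fold higher number from compound 3 to compound 4 (0.29 log units; within the scatter), the first step read at this position. At this position, in this pair, fluorine and methyl on the cyclopropyl ring therefore cannot be told apart. No measured evidence here speaks to why.

Open, going by these compounds, is how an unsubstituted cyclopropyl or a 2-aminocyclopropyl would read on the same carbonyl carbon. Also open, on these data alone, is whether the other arrangement of the two stereocentres would hold this level.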